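Chloro in place of ethyl: from compound 3 to compound 4

This account rests on a few compounds, and the source may have more. Where it says the series, first, only, none or still open, it means among the compounds named here.

Of the compounds shown here, three have so far been tested in a functional assay for inhibition of sodium/hydrogen exchanger (Oryctolagus cuniculus); a higher number here means a weaker inhibitor, a lower number a stronger inhibitor. Compound 1 `CS(=O)(=O)c1cc(C(=O)N=C(N)N)c(Cl)cc1Cl` gives 140 nM. Compound 2 `COc1cc(C)c(C(=O)N=C(N)N)cc1S(C)(=O)=O` gives 16 nM in this assay, and compound 3 `CCc1cc(OC)c(S(C)(=O)=O)cc1C(=O)N=C(N)N` gives 30 nM. Compound 3 therefore holds the second highest of the three numbers: compound 2 is its nearest neighbour, separated by a 1.9-fold higher number from compound 2 to compound 3 (0.27 log units; within the scatter), which reflects methyl in place of hydrogen on a saturated chain carbon bound to an aromatic carbon; compound 1 lies furthest away, with a gap that is beyond the scatter.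

Compound 4 `COc1cc(Cl)c(C(=O)N=C(N)N)cc1S(C)(=O)=O` has not yet been measured. It differs from compound 3 by chloro in place of ethyl on an aromatic carbon. Among the measured compounds shown here, the only measured step touching this position is the one from compound 2 to compound 3, and it stayed within the scatter. Compound 1 also bears chloro, but it differs from the others in more than one place, and compound 1 gives 140 nM, so it offers no single-step guide. Because the step of a 1.9-fold higher number from compound 2 to compound 3 (0.27 log units; within the scatter) stayed within the scatter, no change beyond the scatter is expected here either, so the expected step is a 1.2-fold lower number from compound 3 to compound 4 (0.08 log units; within the scatter). Compound 4 is estimated at 25 nM, with a range from 8 nM to 80 nM.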

Compound 4, half-maximal inhibitory concentration: 40 nM
Estimate against measurement, compound 4: 1.6-fold (0.20 log units) below; the range from low to high includes it.
By their numbers in this assay, from the lowest: compounds 2, 3 and 4 (each within the scatter of the next, the first and the last beyond it); then compound 1.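

Among the compounds shown here, at this position, on the aromatic carbon ortho to a group of 6 heavy atoms, this assay gives a 1.3-fold higher number from compound 3 to compound 4 (0.12 log units; within the scatter) and so does not separate chloro from ethyl, yet a 2.5-fold higher number from compound 2 to compound 4 (0.40 log units; beyond the scatter) is the first step at this position to lie beyond the scatter, a modest one, with ethyl lying within the scatter of both methyl and chloro. Compound 4 also gives compound 1 its first partner differing in one place, and a 3.5-fold lower number from compound 1 to compound 4 (0.54 log units; beyond the scatter) shows that, with chloro held at this position, methoxy in place of the other chloro goes with a modest step to a lower number. Nothing available gives a reason for the size of any of these steps.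

On these data alone, only methyl, ethyl and chloro are seen at this position, so how a longer chain such as propyl, an amine or a bromo would compare stays open. For the compounds shown here, the methoxy step is also seen only with chloro at this position, and whether it would hold with methyl or ethyl there remains unknown.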